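The compounds below may be only part of what the source reports. "The series", "measured", "known", "first", "only" and "open" are said of these compounds alone.

Measured compounds:
compound 1 `CCS(=O)(=O)Nc1cc(C2CCCCC2)cc2c1CCCC2c1c[nH]cn1` — an assay on isolated protein for binding affinity to Alpha-1D adrenergic receptor (Rattus norvegicus), read by radioligand binding; a higher number here means a weaker inhibitor, a lower number a stronger inhibitor: 447 nM
compound 2 `CCCS(=O)(=O)Nc1cccc2c1CCCC2c1c[nH]cn1` — a limit only: < 10000 nM
compound 3 `CCS(=O)(=O)Nc1cccc2c1CCCC2c1c[nH]cn1` — 1070 nM

Compound 3 holds the highest of the two readable numbers; its nearest neighbour is compound 1, separated by a 2.4-fold higher number from compound 1 to compound 3 (0.38 log units; beyond the scatter). The value of compound 2 is a limit of the assay, not a number, so a step that the limit leaves unreadable from compound 2 to compound 3 cannot be sized; see (the limit of < 10000 nM in this assay, at which 1 of the 3 values shown sits).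

Compound 4 `CCS(=O)(=O)Nc1cccc2c1CCCC2(O)c1c[nH]cn1` differs from compound 3 by hydroxy in place of hydrogen on a saturated ring carbon. Neither measured step concerns this saturated ring carbon: one changes the aromatic carbon substituent, the other the chain at the sulfonamide. No guide is therefore available for the size or direction of the step, and the expectation rests on compound 3 alone, allowing a modest move either way.

Compound 4 is thus expected near 1500 nM, within 500 nM to 5000 nM. This estimate corresponds to an expected step of a 1.4-fold higher number from compound 3 to compound 4 (0.15 log units; within the scatter), not clearly beyond the scatter.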

Compound 4, inhibition constant: < 10000 nM
Compound 4 ended at the assay's limit (the forecaster's own chance of this, stated with the estimate: 20%); the middle value lies beyond the limit too.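

In this assay compound 4 gives < 10000 nM, which is a limit and not a number, so no step between compound 3 and compound 4 can be read: the limit of < 10000 nM in this assay, at which 2 of the 4 values shown sit.

The compounds shown leave open the size and direction of the effect of hydroxy in place of hydrogen on a saturated ring carbon.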